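A few compounds are considered here, and "the series" means these few. Any claim that something is new, unique, unknown or untested is made for them only; others in the source may bear on it.

Working notes on a small dihydrofolate reductase series.

Compound 1 `NC1=NC2(CCCCC2)N(c2ccccc2Cl)C(N)=N1` returns only a limit in an assay for inhibition of Dihydrofolate reductase (Bos taurus), using NADPH (a higher number here means a weaker inhibitor, a lower number a stronger inhibitor), namely > 100000 nM. Compound 2 `Cc1ccccc1N1C(N)=NC(N)=NC12CCCCC2` also returns only a limit in this assay, > 100000 nM. The pair differ by methyl in place of chloro on an aromatic carbon, and the resulting step that the two limits leave unreadable from compound 1 to compound 2 cannot be sized, because both values sit at the limit of > 100000 nM in this assay, at which 2 of the 3 values shown sit.

Compound 3 `CC1(C)N=C(N)N=C(N)N1Cc1ccc(Cl)cc1` is built on a different core; the difference between the two cores is not broken down here. In this assay, within the data shown here, compound 3 gives 29900 nM, the only number in the set.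

Compound 4 `Cc1ccc(CN2C(N)=NC(N)=NC2(C)C)cc1` has not yet been measured in this assay. It differs from compound 3 by methyl in place of chloro on an aromatic carbon. Among the measured compounds shown here, this is the same kind of change as the one from compound 1 to compound 2, but the surroundings differ: in compound 4 the exchanged group sits para to a large group, whereas in compound 2 it sits ortho to a large group. The measured instance of the change offers no readable size, so the expectation rests on compound 3 alone, whose value 29900 nM supplies the anchor.

The step from compound 3 to compound 4 is expected to be modest, around a 1.5-fold higher number from compound 3 to compound 4 (0.18 log units; within the scatter), with a real chance that the result again comes back as a limit. Compound 4 is therefore estimated at 45000 nM in this assay, with a plausible range from 15000 nM to 150000 nM.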

Compound 4, half-maximal inhibitory concentration: 24600 nM
Beside the measured number, compound 4's estimate is 1.8-fold (0.26 log units) above it; low and high end bracket the measured number.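

On the core of compound 3, methyl in place of chloro on an aromatic carbon, para to a large group, gives in this assay a 1.2-fold lower number from compound 3 to compound 4 (0.08 log units; within the scatter), so this pair cannot be told apart in this read-out. On the core of compound 1, the same exchange cannot be sized, because compound 1 and compound 2 both return only a limit and no number: the limit of > 100000 nM in this assay, at which 2 of the 4 values shown sit. The series therefore holds one readable instance of the change, which shows that the exchange is tolerated on the core of compound 3 without a separable difference, but it does not show whether the size of the step carries from one core to the other, since there is no second size to set against it.

Still open, from the compounds shown here alone, is whether an amine or a carboxylic acid at the same place on the core of compound 3 would give a step beyond the scatter, given that chloro and methyl alone mark out this position here. Also open, going by these compounds, is whether a longer chain in that place, or any group on the core of compound 1 that returns a number rather than a limit, would allow the two cores to be compared for the same change.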